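A few compounds are considered here, and "the series" means these few. Any claim that something is new, unique, unknown or untested is made for them only; others in the source may bear on it.

Measured compounds in a functional assay on PC-3 cells (Homo sapiens) for antiproliferative activity, read by MTT assay, with a stated time of 48 h; on this read-out higher numbers stand for weaker inhibition and lower numbers for stronger inhibition:

compound 1 `CCN1C(=O)C(O)(Cc2nnn[nH]2)c2cc(Cl)ccc21` — 79300 nM
compound 2 `O=C1N(Cc2ccc(Br)cc2)c2ccc(Cl)cc2C1(O)Cc1nnn[nH]1` — 87900 nM

Compound 1 gives the lowest of the two numbers; compound 2 sits a 1.1-fold higher number from compound 1 to compound 2 (0.04 log units; within the scatter) away, so the two are indistinguishable. Compound 3 `CCN1C(=O)C(O)(Cc2nnn[nH]2)c2cc(C)ccc21` differs from compound 1 by methyl in place of chloro on an aromatic carbon. Among the compounds with values here, no measured step touches this aromatic position; the only step recorded, from compound 1 to compound 2, concerns the group on the ring nitrogen and stayed within the scatter. With nothing to argue for a shift in either direction, compound 3 is expected to lie close to compound 1 in this assay, as an estimated step of a 1.0-fold higher number from compound 1 to compound 3 (0.00 log units; within the scatter). The estimate for compound 3 is 80000 nM, within 35000 nM to 180000 nM.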

Compound 3, half-maximal inhibitory concentration: > 100000 nM
Compound 3: no number, only a limit; the forecaster's own chance of this, stated with the estimate: 15%; middle value at least 1.2-fold (0.09 log units) away from the limit.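

In this assay compound 3 gives > 100000 nM as a limit of the assay and not a number. Methyl in place of chloro on the aromatic carbon is the first change read at this position, giving an at least 1.2-fold higher number from compound 1 to compound 3 (0.10 log units; that floor lies within the scatter) and leaving the true size of the step unknown, with a floor that does not separate the two compounds. The series meets this ceiling once: the limit of > 100000 nM in this assay, at which 1 of the 3 values shown sits.

Still open, going by these compounds, is how an amine or a methoxy group on this aromatic carbon would read against the chloro of compound 1.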